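Nitrooxymethylphenyl Ester in Place of Methoxyphenyl Ester

A few compounds are considered here, and "the series" means these few. Any claim that something is new, unique, unknown or untested is made for them only; others in the source may bear on it.

Compound 1 `CC(=O)Oc1ccccc1C(=O)O[C@H]1CO[C@H]2[C@@H]1OC[C@H]2O` carries hydrogen on an oxygen on a saturated carbon of the shared core. In an ADME assay on a cell-free system (plasma, Homo sapiens) for metabolic stability, with Plasma (Rattus norvegicus) as the target, read by HPLC, at pH 7.4 (a lower number here means that the compound disappears faster, a higher number that the compound lasts longer), compound 1 gives 0.0183 h. Compound 2 `COc1ccc(C(=O)O[C@@H]2CO[C@H]3[C@@H]2OC[C@@H]3OC(=O)c2ccccc2OC(C)=O)cc1` carries (4-methoxyphenyl)carbonyl in place of that hydrogen, and in this assay compound 2 gives 0.0183 h; the step of no change at the digits printed from compound 1 to compound 2 (within the scatter) shows that this addition left the half-life where it was, so compound 2 stands level with compound 1 on the numbers measured.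

Compound 3 `CC(=O)Oc1ccccc1C(=O)O[C@H]1CO[C@H]2[C@@H]1OC[C@H]2OC(=O)c1ccccc1CO[N+](=O)[O-]` differs from compound 2 by 2-((nitrooxy)methyl)phenyl in place of 4-methoxyphenyl on a carbonyl carbon. Going by the values given here, the only measured step, no change at the digits printed from compound 1 to compound 2 (within the scatter), concerns the oxygen on a saturated carbon and changed nothing within the scatter; no measured step bears on an exchange of one aryl group for another on the carbonyl carbon once the ester is present. With both measured compounds disappearing at the same short half-life, the expectation for compound 3 is that it disappears at a similar rate, with a 1.0-fold lower number from compound 2 to compound 3 (0.01 log units; within the scatter) expected to lie within the scatter. In this assay compound 3 is therefore estimated at 0.018 h, with a range from 0.009 h to 0.04 h.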

Compound 3, half-life: 0.0533 h
For compound 3 the middle estimate is 3.0-fold (0.47 log units) below the measured one; the whole stated range lies below it.
By their numbers in this assay, from the lowest: compounds 1 and 2 (each within the scatter of the next); then compound 3.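

In this assay, the aryl group on this carbonyl carbon, whose other neighbour is an oxygen next to a carbonyl group, proves able to move the read-out. Going by these compounds alone, exchanging 4-methoxyphenyl for 2-((nitrooxy)methyl)phenyl gives a 2.9-fold higher number from compound 2 to compound 3 (0.46 log units; beyond the scatter), whereas the only earlier step, made at the oxygen on a saturated carbon, gave no change at the digits printed from compound 1 to compound 2 (within the scatter), so the half-life responds to this change in a way the first pair gave no sign of, though the step is modest and rests on a single pair. Nothing available here accounts for the step.

The compounds shown leave open whether the whole of 2-((nitrooxy)methyl)phenyl is needed for this longer half-life, as a pair with 2-methylphenyl or 2-(hydroxymethyl)phenyl on the same carbonyl carbon would be required to separate the nitrooxy group from the rest of the substituent. They also leave open how the half-life would respond to a longer chain carrying the nitrooxy group, or to an amine or a carboxylic acid on the aryl ring.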